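From Methoxy to Ethoxy on the Shared Core

This account rests on a few compounds, and the source may have more. Where it says the series, first, only, none or still open, it means among the compounds named here.

Results in a physicochemical assay for lipophilicity, read by HPLC, at pH 7.4 (a higher number here means a more lipophilic compound, a lower number a more polar compound), so far
compound 1 `CC(C)Cc1cc2oc(=O)n(CCC(=O)O)c2cc1Cl` at 3.03
compound 2 `C[C@@H](Oc1cc2oc(=O)n(CCC(=O)O)c2cc1Cl)c1cccnn1` at 0.83
compound 3 `COc1cc2oc(=O)n(CCC(=O)O)c2cc1Cl` reads "not determined" (no result reported)

Compound 3 has no place on the scale, as no result was reported for it. Compound 4 `CCOc1cc2oc(=O)n(CCC(=O)O)c2cc1Cl` remains unmeasured. The change is methyl in place of hydrogen on a saturated chain carbon bound to an oxygen on an aromatic ring in the passage from methoxy to ethoxy, that is, methyl in place of hydrogen on a saturated chain carbon bound to an oxygen on an aromatic ring. A small rise in this assay is expected for this step, close to the usual scatter. With no starting number, the expectation has only two anchors, compound 2 at 0.83 and compound 1 at 3.03 on the same scale. Compound 4 is expected at 1.8 within an estimated range of 1.3 to 2.3 once measured.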

Compound 4, distribution coefficient: 1.49
Estimate against measurement, compound 4: 0.31 log units above, within the range that was stated.
By their numbers in this assay, from the lowest: compound 2; then compound 4; then compound 1.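

With compound 4, ethoxy on the shared core gains a place on the scale of this assay. Hydrogen in place of pyridazin-3-yl on the saturated chain carbon bound to the oxygen gives a modest rise (a number 0.66 log units higher from compound 2 to compound 4 (beyond the scatter)), while ethoxy in place of isobutyl on an aromatic carbon gives a large fall (a number 1.54 log units lower from compound 1 to compound 4 (beyond the scatter)). The step from methoxy to ethoxy still cannot be read, as compound 3 has no number.

As far as these compounds go, whether a longer chain such as propoxy, or an amine at this place, would continue these readings remains open. Nothing at hand accounts for the size of either step.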